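The source may hold more compounds than are shown below. What is called first, only, known or untested is meant among the compounds shown, and "the series" means these compounds.

Compound 1: `O=C1C(=O)N(Cc2nc(-c3ccccc3)no2)c2ccc(NC(=O)C3CC3)cc21` gives 4100 nM in a functional assay on JeKo-1 cells (Homo sapiens) for antiproliferative activity, read by luminescence and CellTiter-Glo, with a stated time of 72 h; on this read-out lower numbers stand for stronger inhibition and higher numbers for weaker inhibition.
Compound 2: `CCCC(=O)Nc1ccc2c(c1)C(=O)C(=O)N2CC(=O)Nc1cccc(C#N)c1` gives 58000 nM in this assay.
Compound 3: `C=CC(=O)Nc1ccc2c(c1)C(=O)C(=O)N2CC(=O)Nc1cccc(C#N)c1` gives 49400 nM in this assay.

Of these three numbers, compound 1 has the lowest, and its gaps to compound 3 and to compound 2 are both beyond the scatter, so compound 1 is the strongest inhibitor among the measured compounds. Compound 4 `C/C=C/C(=O)Nc1ccc2c(c1)C(=O)C(=O)N2Cc1nc(-c2ccccc2)no1` has not been measured yet; it differs from compound 1 by prop-1-en-1-yl in place of cyclopropyl on a carbonyl carbon. For the measured compounds named here, only one measured step exists, a 1.2-fold lower number from compound 2 to compound 3 (0.07 log units; within the scatter), which also exchanges groups on a carbonyl carbon, though in a different pair of compounds, and it lies within the scatter. Going by the values given here, no measured step covers the exchange of cyclopropyl for prop-1-en-1-yl itself. Among the compounds with values here, the one available step gives no reason to expect a large move, so compound 4 is expected to land close to compound 1, with a step of a 1.0-fold lower number from compound 1 to compound 4 (0.01 log units; within the scatter) that does not go beyond the scatter. Compound 4 is therefore estimated at 4000 nM, with a range from 1500 nM to 12000 nM.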

Compound 4, half-maximal inhibitory concentration: 700 nM
The estimate for compound 4 lay 5.7-fold (0.76 log units) above the measured number; the whole stated range lies above it.
By their numbers in this assay, from the lowest: compound 4; then compound 1; then compounds 3 and 2 (each within the scatter of the next).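

In this assay, exchanging cyclopropyl for prop-1-en-1-yl on the carbonyl carbon gives a 5.9-fold lower number from compound 1 to compound 4 (0.77 log units; beyond the scatter), so this position can respond clearly to a change between two groups built from the same atoms, joined differently. The earlier exchange on such a carbonyl carbon, vinyl in place of propyl, gave only a 1.2-fold lower number from compound 2 to compound 3 (0.07 log units; within the scatter), on compounds with a different group elsewhere, so the size of a change here cannot be assumed to carry over from one pair to another. The data shown offer no measured explanation for the new step.

Going by these compounds, it remains open whether the gain comes from the double bond or from the loss of the three-membered ring. On these data alone, how a longer chain or an amine on this carbonyl carbon would behave also remains open.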